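Bromo to methoxycarbonyl on the ethenyl chain: an expectation

The source may hold more compounds than are shown below. What is called first, only, known or untested is meant among the compounds shown, and "the series" means these compounds.

Compound 1 `O=c1[nH]c(=O)n(C2C[C@@H](O)[C@@H](CO)O2)nc1/C=C/Br`: 355 ug/mL
Compound 2 `CS/C=C/c1nn(C2C[C@@H](O)[C@@H](CO)O2)c(=O)[nH]c1=O`: 420 ug/mL
Compound 3 `O=C(O)/C=C/c1nn(C2C[C@@H](O)[C@@H](CO)O2)c(=O)[nH]c1=O`: a limit of the assay, > 500 ug/mL

All three share one core and differ only in the group on the ethenyl chain. In a functional assay on Vero cells (Chlorocebus sabaeus) for cytotoxicity (a higher number here means a weaker inhibitor, a lower number a stronger inhibitor), compound 1 has the smaller of the two plain numbers, yet the step of a 1.2-fold higher number from compound 1 to compound 2 (0.07 log units; within the scatter) lies within the scatter, so compounds 1 and 2 are not distinguishable. For compound 3 the assay reports only a limit and no number (the limit of > 500 ug/mL in this assay, at which 1 of the 3 values shown sits). The step of an at least 1.4-fold higher number from compound 1 to compound 3 (0.14 log units; that floor lies within the scatter) is therefore a floor, and that floor also sits within the scatter.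

Compound 4 `COC(=O)/C=C/c1nn(C2C[C@@H](O)[C@@H](CO)O2)c(=O)[nH]c1=O` has not been measured. It differs from compound 1 in one place: methoxycarbonyl in place of bromo on a double-bonded chain carbon bound to a double-bonded chain carbon. The nearest measured step replaces the same bromo with a carboxy, an at least 1.4-fold higher number from compound 1 to compound 3 (0.14 log units; that floor lies within the scatter), and the methylsulfanyl swap, a 1.2-fold higher number from compound 1 to compound 2 (0.07 log units; within the scatter), is equally small. Both point to no step beyond the scatter, with the number possibly drifting up toward the limit. Compound 4 is thus expected to give about 430 ug/mL, within a range from 220 ug/mL to 850 ug/mL. The step this estimate implies is a 1.2-fold higher number from compound 1 to compound 4 (0.08 log units; within the scatter).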

Compound 4, concentration for 50% inhibition: > 500 ug/mL
Compound 4: a limit, no number (the forecaster's own chance of this, stated with the estimate: 45%); middle value at least 1.1-fold (0.06 log units) from the limit.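

With methoxycarbonyl on the ethenyl chain, this assay gives a limit rather than a number for a second group, after the carboxy of compound 3: the limit of > 500 ug/mL in this assay, at which 2 of the 4 values shown sit. What compound 4 adds is that the two steps to it, an at least 1.4-fold higher number from compound 1 to compound 4 (0.14 log units; that floor lies within the scatter) and an at least 1.1-fold higher number from compound 2 to compound 4 (0.07 log units; that floor lies within the scatter), are only floors, so the true size of each step could be larger but is not shown. The step from compound 3 to compound 4, methyl in place of hydrogen on an oxygen next to a carbonyl group, cannot be read.

As far as these compounds go, how far the true values of compound 3 and compound 4 lie past the limit stays open. Also open, from the compounds shown here alone, is whether an amine or a longer chain in place of bromo would give a step beyond the scatter in either direction.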